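Adding a nitrooxy group to a quinazolinone urea

The source may report more compounds than this note shows. Statements on the series, on what has been measured and on what is new or still open speak of the compounds shown alone.

Of the compounds shown here, three built on the same core have been tested in a functional assay on the whole organism (strain Sprague-Dawley) for inhibition, with Rattus norvegicus as the target, read by paw edema, with stated times of 30 min and 3 h, at a dose of 80 mg/kg by the oral route; a higher number here means more inhibition at the dose given (going by the name of the read-out), a lower number less inhibition. Compound 1, with the structure `Cc1nc2ccccc2c(=O)n1NC(=O)NC1CCCCC1`, gives 54.8% in this assay. Compound 2, with the structure `Cc1nc2ccccc2c(=O)n1NC(=S)Nc1ccccc1`, gives 61.9%, and compound 3, with the structure `CC(=O)Nc1ccc(S(=O)(=O)Nn2c(C)nc3ccccc3c2=O)cc1`, gives 59.2%. Compound 1 carries the smallest of these three numbers, but its gaps to compound 3 and to compound 2 both sit inside the usual scatter of such measurements, so the three compounds cannot be told apart on these data.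

Compound 4, with the structure `O=C(NC1CCCCC1)Nn1c(CO[N+](=O)[O-])nc2ccccc2c1=O`, has not yet been measured. It differs from compound 1 in one place: nitrooxy in place of hydrogen on a saturated chain carbon bound to an aromatic carbon. The urea and the cyclohexyl group of compound 1 are kept; only the methyl on the core is changed.

For the measured compounds named here, no pair of measured compounds differs in a single place, so there is no measured step to lean on. With the three numbers so close together, the step from compound 1 to compound 4 is expected to be small, a number 2.2 percentage points higher from compound 1 to compound 4 (within the scatter), and not beyond the scatter in either direction. Compound 4 is therefore estimated to give about 57% in this assay, with a range from 44% to 70%.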

Compound 4, a percentage reported as inhibition, in the whole organism at one dose (the size of the read-out at that dose, not a potency): 49.9%
Beside the measured number, compound 4's estimate is 7.1 percentage points above it; measured number inside the range.
By their numbers in this assay, from the lowest: compounds 4, 1, 3 and 2 (each within the scatter of the next, the first and the last beyond it).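

For the compounds shown here, this is the first measured step at this position: in this assay, the change from methyl to (nitrooxy)methyl gives a number 4.9 percentage points lower from compound 1 to compound 4 (within the scatter). Inhibition of the paw edema therefore remains clearly present with a nitrooxy group on a saturated chain carbon bound to an aromatic carbon, and the step is too small to count as either a gain or a loss at this single dose. Nothing available here gives a reason for this result.

A single step cannot show whether other groups at this position would move the number beyond the usual scatter, such as an amine or a carboxylic acid on the same carbon, or a longer chain carrying the nitrooxy group. It also leaves open whether the same change would behave alike with the thiourea of compound 2 or the sulfonamide of compound 3, since the urea and cyclohexyl group of compound 1 are the only setting in which it has been read here.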